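The source may hold more compounds than are shown below. What is called first, only, known or untested is meant among the compounds shown, and "the series" means these compounds.

Measured compounds and their results:
compound 1, `Cc1cccc(-c2onc3ccc(C(=O)O)cc23)c1` — 150 nM
compound 2, `O=C(O)c1ccc2noc(-c3cccc(NC(=O)C4CC4)c3)c2c1` — 410 nM
compound 3, `O=C(O)c1ccc2noc(-c3cccc(Oc4ccccc4)c3)c2c1` — 130 nM

In an assay for inhibition of inositol hexakisphosphate kinase 2 (Homo sapiens), read by colorimetric assay, coupled enzyme assay and malachite green, with a stated time of 120 min, in the presence of a further agent that is not named here (on this read-out lower numbers stand for stronger inhibition and higher numbers for weaker inhibition), compound 3 gives 130 nM, the lowest of the three numbers. Compound 1 gives 150 nM, and the step of a 1.2-fold lower number from compound 1 to compound 3 (0.06 log units; within the scatter) lies within the scatter, so the two cannot be ranked. Compound 2 gives 410 nM, and the step of a 3.2-fold lower number from compound 2 to compound 3 (0.50 log units; beyond the scatter) is modest but beyond the scatter, as is a 2.7-fold higher number from compound 1 to compound 2 (0.44 log units; beyond the scatter).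

Compound 4, `O=C(O)c1ccc2noc(-c3cccc(Oc4ncc(Cl)cc4Cl)c3)c2c1`, differs from compound 3 in one place: 3,5-dichloropyridin-2-yl in place of phenyl on an oxygen on an aromatic ring. Among the measured compounds shown here, no measured step alters the ring on that oxygen; all three measured steps exchange the whole group on the aromatic carbon of the pendant ring, where phenoxy and methyl sit together within the scatter and only the amide moves the number upward. For the measured compounds named here, the change from compound 3 to compound 4 therefore has no direct precedent here, and the closest guide is that compound 3 and compound 1, the two compounds without an amide, sit close to each other. With an unchanged phenoxy linkage and only the ring at its far end replaced, compound 4 is expected to stay near compound 3, with the estimated step of a 1.2-fold lower number from compound 3 to compound 4 (0.07 log units; within the scatter) not exceeding the scatter. Compound 4 is thus estimated at 110 nM, within a range from 40 nM to 350 nM.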

Compound 4, half-maximal inhibitory concentration: 71 nM
The estimate for compound 4 lay 1.5-fold (0.19 log units) above the measured number; the measured number falls inside the stated range.
By their numbers in this assay, from the lowest: compounds 4, 3 and 1 (each within the scatter of the next, the first and the last beyond it); then compound 2.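

In this assay, exchanging the ring on the oxygen while keeping the linkage gives a 1.8-fold lower number from compound 3 to compound 4 (0.26 log units; within the scatter), so replacing phenyl with 3,5-dichloropyridin-2-yl, a change with more heavy atoms and a hydrogen-bond acceptor, cannot be distinguished from no change on this read-out. The exchange does alter how the whole group compares with the other groups on the aromatic carbon: phenoxy could not be separated from methyl, at a 1.2-fold lower number from compound 1 to compound 3 (0.06 log units; within the scatter), whereas (3,5-dichloropyridin-2-yl)oxy can, at a 2.1-fold lower number from compound 1 to compound 4 (0.32 log units; beyond the scatter), and its replacement of the amide gives a 5.8-fold lower number from compound 2 to compound 4 (0.76 log units; beyond the scatter). The data given offer no explanation for these differences.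

The compounds shown do not separate the contribution of the ring nitrogen from that of the two chlorines, which a pyridin-2-yl or a 3,5-dichlorophenyl group on the same oxygen could do. They also leave open how the number responds to a change at the carboxylic acid shared by all four compounds, for example to a methyl ester or a tetrazole.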